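Benzylamine esters against serine protease 1: pentyl ester

This account rests on a few compounds, and the source may have more. Where it says the series, first, only, none or still open, it means among the compounds named here.

Measured so far:
compound 1 `NCc1ccc(C(=O)OCc2ccc(Cl)cc2)cc1`: 30000000 nM
compound 2 `NCc1ccc(C(=O)OCCCc2ccccc2)cc1`: 500000000 nM

In an assay on isolated protein for inhibition of serine protease 1 (Homo sapiens) (a lower number here means a stronger inhibitor, a higher number a weaker inhibitor), compound 2 gives 500000000 nM, the higher of the two numbers; compound 1 gives 30000000 nM, and the gap between them lies beyond the scatter. Compound 3 `CCCCCOC(=O)c1ccc(CN)cc1` is not yet measured. It differs from compound 2 by ethyl in place of phenyl on a saturated chain carbon, three bonds along the chain from an oxygen next to a carbonyl group. Among the measured compounds shown here, no step of this kind has been measured, so the size and direction of the change in this assay are open. Compound 3 is expected near 300000000 nM, between 50000000 nM and 2000000000 nM. This estimate means a step of a 1.7-fold lower number from compound 2 to compound 3 (0.22 log units; within the scatter), small against the scatter.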

Compound 3, inhibition constant: 700000000 nM
The estimate for compound 3 lay 2.3-fold (0.37 log units) below the measured number; low and high end bracket the measured number.
By their numbers in this assay, from the lowest: compound 1; then compounds 2 and 3 (each within the scatter of the next).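

In this assay the exchange of phenyl for ethyl on a saturated chain carbon, three bonds along the chain from an oxygen next to a carbonyl group, gives a 1.4-fold higher number from compound 2 to compound 3 (0.15 log units; within the scatter) and so no step beyond the scatter. At this place, the six-membered aromatic ring of compound 2 is therefore not needed to keep the number seen there. Nothing available bears on the reason for this.

From the compounds shown here alone, whether an amine, a carboxylic acid or a longer chain at this carbon would give a step beyond the scatter remains open.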